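A few compounds are considered here, and "the series" means these few. Any claim that something is new, unique, unknown or untested is made for them only; others in the source may bear on it.

For the measured compounds named here, compound 3, `Oc1ccccc1-c1cc(-c2ccc(OC(F)(F)F)cc2)cc(-c2ccccc2O)n1`, is the only compound here with a number in a functional assay on DU-145 cells (Homo sapiens) for inhibition; a lower number here means a stronger inhibitor, a higher number a weaker inhibitor: compound 3 gives 20300 nM. Compound 1, `Oc1cccc(-c2cc(-c3ccc(F)cc3)cc(-c3ccccc3O)n2)c1`, gives > 50000 nM, which is a limit of the assay and not a number. Compound 2, `Oc1cccc(-c2cc(-c3ccc(C(F)(F)F)cc3)cc(-c3ccccc3O)n2)c1`, likewise gives > 50000 nM, again a limit. Going by the values given here, the one measured step, a step that the two limits leave unreadable from compound 1 to compound 2, concerns a different change and stays unreadable, so it gives no guide to the size expected. Compound 4, `Oc1cccc(-c2cc(-c3ccc(OC(F)(F)F)cc3)cc(-c3ccccc3O)n2)c1`, differs from compound 3 by 3-hydroxyphenyl in place of 2-hydroxyphenyl on an aromatic carbon. Compounds 1 and 2 carry the same 3-hydroxyphenyl arrangement as compound 4 and both sit at the limit of > 50000 nM in this assay, at which 2 of the 3 values shown sit. A weakening step a 2.5-fold higher number from compound 3 to compound 4 (0.39 log units; beyond the scatter) is therefore expected, with a real chance that only a limit is reported. Compound 4 is estimated at 50000 nM, within 15000 nM to 150000 nM.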

Compound 4, half-maximal inhibitory concentration: 21100 nM
Compound 4: middle estimate off by 2.4-fold (0.37 log units), on the high side, and the stated range covers the measured number.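

In this assay, putting 3-hydroxyphenyl in place of 2-hydroxyphenyl next to the ring nitrogen shows no real effect: a 1.0-fold higher number from compound 3 to compound 4 (0.02 log units; within the scatter). With 3-hydroxyphenyl held fixed, the other group does matter, with trifluoromethoxy in place of trifluoromethyl giving an at least 2.3-fold lower number from compound 2 to compound 4 (0.37 log units; beyond the scatter) and trifluoromethoxy in place of fluoro giving an at least 2.3-fold lower number from compound 1 to compound 4 (0.37 log units; beyond the scatter). Compound 1 and compound 2 give limits rather than numbers: the limit of > 50000 nM in this assay, at which 2 of the 4 values shown sit.

Going by these compounds, it remains open how an amine or a carboxylic acid in place of the hydroxyl would behave in this assay. On these data alone, it is also open whether 2-hydroxyphenyl and 3-hydroxyphenyl would stay level alongside fluoro or trifluoromethyl.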